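The source may report more compounds than this note shows. Statements on the series, on what has been measured and on what is new or still open speak of the compounds shown alone.

In an ADME assay on Jurkat cells (Homo sapiens) for cytotoxicity, read by trypan blue exclusion, with a stated time of 24 h (a lower number here means a stronger inhibitor, a higher number a weaker inhibitor), compound 1 (`N#C[Se]Cc1ccc([N+](=O)[O-])cc1`) gives 6860 nM and compound 2 (`N#C[Se]Cc1ccccc1[N+](=O)[O-]`) gives 12900 nM. These two values lie within the usual scatter of each other, so the data do not separate them, and compound 1 cannot be ranked on these numbers. The next compound to be tested is compound 3 (`N#C[Se]Cc1ccc(Br)cc1`), which carries bromo in place of nitro on an aromatic carbon. Going by the values given here, no measured pair of compounds shows what this change does on its own, so the only guide is the value of compound 1 at 6860 nM. The expected 1.2-fold higher number from compound 1 to compound 3 (0.07 log units; within the scatter) is therefore none beyond the scatter, in either direction. For compound 3 the estimated value is 8000 nM, with an expected range from 3000 nM to 20000 nM.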

Compound 3, half-maximal inhibitory concentration: 12700 nM
Compound 3: the middle estimate sits 1.6-fold (0.20 log units) below what was measured, and the stated range covers the measured number.
By their numbers in this assay, from the lowest: compounds 1, 3 and 2 (each within the scatter of the next).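

Going by these compounds alone, this is the first step measured at this position, para to a group of 4 heavy atoms, and it replaces nitro, which has 3 heavy atoms and 2 hydrogen-bond acceptors, with bromo, a single atom with no acceptors. In this assay the swap gives a 1.9-fold higher number from compound 1 to compound 3 (0.27 log units; within the scatter), so the data do not separate the two compounds, and this one pair shows that two groups this different in makeup can give numbers within the usual scatter of each other. Nothing measured here offers an explanation for this result.

The compounds shown leave open whether any group is needed at this position, since plain hydrogen there is not among them. They also leave open whether an amine or a carboxylic acid in the same place would give a number beyond the scatter from compound 1.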